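A few compounds are considered here, and "the series" means these few. Any claim that something is new, unique, unknown or untested is made for them only; others in the source may bear on it.

Measured so far in a functional assay on DU-145 cells (Homo sapiens) for inhibition, read by trypan blue exclusion, with a stated time of 96 h; a lower number here means a stronger inhibitor of growth, a higher number a weaker inhibitor of growth:
Compound 1 `Cc1ccc(S(=O)(=O)/C(=C/c2ccc(C)s2)C(=O)c2ccc(Cl)cc2)cc1` gives 50000 nM
Compound 2 `Cc1ccc(S(=O)(=O)/C(=C/c2ccc(Cl)cc2)C(=O)c2ccc(Cl)cc2)cc1` gives 1000 nM

Within the data shown here, of these two, compound 2 has the lower number and is the stronger inhibitor of growth, and compound 1 is its only neighbour on the scale. The next compound is compound 3 `Cc1ccc(S(=O)(=O)/C(=C/c2ccc(Oc3ccccc3)cc2)C(=O)c2ccc(Cl)cc2)cc1` with the difference phenoxy in place of chloro on an aromatic carbon in which phenoxy takes the place of chloro on an aromatic carbon, para to a large group.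

Among the measured compounds shown here, only one measured step bears on this change. That step, a 50-fold lower number from compound 1 to compound 2 (1.70 log units; beyond the scatter), is large, and it exchanged the whole group that compound 3 now alters. For the measured compounds named here, no measured step replaces chloro itself, so the evidence is thin. The ring that carries the chloro stays in compound 3, so a step of that size is not expected. A moderate move toward a higher number is expected instead, and a result within the scatter remains possible.

The expected move is a 2.5-fold higher number from compound 2 to compound 3 (0.40 log units; beyond the scatter) on this estimate. For compound 3 the estimated value is 2500 nM with an expected range of 500 nM to 12000 nM around it.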

Compound 3, concentration for 50% growth inhibition: 1000 nM
For compound 3 the middle estimate is 2.5-fold (0.40 log units) above the measured one, within the range that was stated.
By their numbers in this assay, from the lowest: compounds 2 and 3 (each within the scatter of the next); then compound 1.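

In this assay, replacing chloro with phenoxy on the aromatic carbon gives no change at the digits printed from compound 2 to compound 3 (within the scatter) and so leaves the number unchanged, although the entering group has 7 heavy atoms and a six-membered aromatic ring of its own where the leaving group has 1 heavy atom and no ring. The earlier step, a 50-fold lower number from compound 1 to compound 2 (1.70 log units; beyond the scatter), exchanged the whole group on the double-bonded chain carbon and could not separate the ring from what it carries, whereas this step alters only the substituent and shows that, for these two substituents, the number does not respond to the difference in size. The data offer nothing measured that accounts for this lack of response.

With only chloro and phenoxy shown on this aromatic carbon, it remains open whether a group of another kind, such as an amine, a carboxylic acid or a longer alkoxy chain, would hold the same level in this cell assay. On these data alone, it is also open whether phenoxy would give the same result on the 5-methylthiophen-2-yl ring of compound 1, or whether its match with chloro holds only on the six-membered ring.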